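This account rests on a few compounds, and the source may have more. Where it says the series, first, only, none or still open, it means among the compounds named here.

Of the compounds shown here, three sharing one core have been tested in a functional assay on HepG2 cells (Homo sapiens) for antiproliferative activity, read by CCK-8 assay, with a stated time of 48 h; on this read-out higher numbers stand for weaker inhibition and lower numbers for stronger inhibition. Compound 1 `COc1ccc(/C=C\c2cc(OC)c(OC)c(OC)c2)cc1OCc1ccc(CN2CCCCC2C(=O)O)cc1` gives 3100 nM, and compound 3 `COc1ccc(/C=C\c2cc(OC)c(OC)c(OC)c2)cc1OCc1ccc(CNCCNC(C)=O)cc1` gives 6100 nM. These two cannot be told apart, since the difference is a 2.0-fold higher number from compound 1 to compound 3 (0.29 log units; within the scatter). Compound 2 `COc1ccc(/C=C\c2cc(OC)c(OC)c(OC)c2)cc1OCc1ccc(CN[C@H](C(=O)O)[C@H](C)O)cc1` returned only a limit, > 10000 nM.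

Compound 4 `COc1ccc(/C=C\c2cc(OC)c(OC)c(OC)c2)cc1OCc1ccc(CN2CC[C@@H](C(=O)O)C2)cc1` changes compound 3 in one place: 3-carboxypyrrolidin-1-yl in place of (2-acetamidoethyl)amino on a saturated chain carbon bound to an aromatic carbon. In words, 3-carboxypyrrolidin-1-yl takes the place of (2-acetamidoethyl)amino on a saturated chain carbon bound to an aromatic carbon.

The closest guide is the measured swap between 2-carboxypiperidin-1-yl and that same (2-acetamidoethyl)amino, which is a 2.0-fold higher number from compound 1 to compound 3 (0.29 log units; within the scatter). It runs in the opposite sense to the new change, and it stays small. A note of caution comes from the open-chain group of compound 2, where the swap from the 2-carboxypiperidin-1-yl group gives an at least 3.2-fold higher number from compound 1 to compound 2 (0.50 log units; beyond the scatter). The remaining measured step is an at least 1.6-fold lower number from compound 2 to compound 3 (0.21 log units; that floor lies within the scatter).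

On this evidence, no change beyond the scatter is expected, and the estimated step is a 1.2-fold lower number from compound 3 to compound 4 (0.09 log units; within the scatter). For compound 4 the expected value is 5000 nM, with an estimated range from 2000 nM to 12000 nM.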

Compound 4, half-maximal inhibitory concentration: 2300 nM
For compound 4 the middle estimate is 2.2-fold (0.34 log units) above the measured one; the measured number falls inside the stated range.
By their numbers in this assay, from the lowest: compounds 4, 1 and 3 (each within the scatter of the next, the first and the last beyond it). At a limit, above all of these: compound 2.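

In this assay, the change from the ringless (2-acetamidoethyl)amino to 3-carboxypyrrolidin-1-yl, on a saturated chain carbon bound to an aromatic carbon, gives a 2.7-fold lower number from compound 3 to compound 4 (0.42 log units; beyond the scatter), the first step away from that group that clearly exceeds the scatter. The two ring acids cannot be told apart, with a 1.3-fold lower number from compound 1 to compound 4 (0.13 log units; within the scatter), so compound 1 and compound 4 show that this position accepts either ring, while the step from compound 1 to compound 3 stayed within the scatter. Compound 2 gives only a limit, so its gap to the ring acid, an at least 4.3-fold lower number from compound 2 to compound 4 (0.63 log units; beyond the scatter), is a floor, and the limit reads: the limit of > 10000 nM in this assay, at which 1 of the 4 values shown sits.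

The change to compound 4 brings in a ring and a carboxylic acid together, and only a plain pyrrolidin-1-yl group without the acid, or an open-chain amine carrying the same acid, could separate the two. The compounds shown also leave open whether the defined stereocentre matters, since the mirror-image 3-carboxypyrrolidin-1-yl group is not among them.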